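Fluorinated short-chain alcohols: working notes on lipophilicity

The compounds below may be only part of what the source reports. "The series", "measured", "known", "first", "only" and "open" are said of these compounds alone.

Measured so far:
Compound 1, `OCCCC(F)CF`, gives 0.11 in a physicochemical assay for lipophilicity, read by NMR; on this read-out higher numbers stand for higher lipophilicity and lower numbers for lower lipophilicity.
Compound 2, `CCC(F)CO`, gives 0.26 in this assay.

Compound 2 stands highest of the two numbers. Its nearest neighbour is compound 1, whose value lies lower by an amount within the usual scatter, so no order between the two is claimed.

Compound 3, `CCC(F)(F)CO`, is not yet measured. Compared with compound 2 the change is fluoro in place of hydrogen on a saturated chain carbon bound to a fluorine atom and two saturated chain carbons. Among the measured compounds shown here, no step between measured compounds is available to lean on here, so the expectation rests on the structural change alone.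

The step from compound 2 to compound 3 is expected to be a number 0.29 log units higher from compound 2 to compound 3 (within the scatter), a modest rise that may not clear the scatter. Compound 3 is estimated at 0.55, with a range from 0.25 to 0.85.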

Compound 3, partition coefficient: 0.67
Compound 3: middle estimate off by 0.12 log units, on the low side; the range from low to high includes it.
By their numbers in this assay, from the lowest: compounds 1 and 2 (each within the scatter of the next); then compound 3.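

In this assay, among the compounds shown here, fluoro in place of hydrogen on a saturated chain carbon bound to a fluorine atom and two saturated chain carbons gives a number 0.41 log units higher from compound 2 to compound 3 (beyond the scatter) and is the first step that clears the scatter. For the compounds shown here, it is also the first step read at a single place, as compound 1 and compound 2 differ in more than one place and yield no such step. The measurements shown offer no explanation for this step.

One step at one carbon leaves open whether the same change gives a step of similar size on a longer chain. It also leaves open how chloro at this carbon, or an amine in place of the alcohol, would read in this assay.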